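Purine guanidines: alkylating the exocyclic amine of compound 2

The compounds below may be only part of what the source reports. "The series", "measured", "known", "first", "only" and "open" are said of these compounds alone.

Measured so far:
- compound 1, `Cn1cnc2c(NC(=N)N)nc(N)nc21`: > 100000 nM in a functional assay on MCF7 cells (Homo sapiens) for inhibition, read by fluorescence, with a stated time of 72 h; a lower number here means a stronger inhibitor, a higher number a weaker inhibitor
- compound 2, `CC(C)n1cnc2c(NC(=N)N)nc(N)nc21`: 97200 nM in this assay

The value of compound 1 is a limit of this assay, not a number. Among the measured compounds shown here, compound 2 therefore holds the only number in this assay, and that number sits at the weak end of what the assay reports. For the measured compounds named here, the single step, an at least 1.0-fold lower number from compound 1 to compound 2 (0.01 log units; that floor lies within the scatter), lies within the scatter and says nothing about the exocyclic nitrogen.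

Compound 3, `CC[C@H](CO)Nc1nc(NC(=N)N)c2ncn(C(C)C)c2n1`, differs from compound 2 by 1-(hydroxymethyl)propyl in place of hydrogen on a nitrogen on an aromatic ring. Going by the values given here, no measured step touches this nitrogen, so the expectation rests only on the structural change itself. A modest move toward a lower number is expected, a 3.2-fold lower number from compound 2 to compound 3 (0.51 log units; beyond the scatter), with wide uncertainty. Compound 3 is estimated at 30000 nM, between 5000 nM and 100000 nM, and a limit in this assay remains a real possibility.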

Compound 3, half-maximal inhibitory concentration: 4500 nM
Estimate against measurement, compound 3: 6.7-fold (0.82 log units) above; measured number below the stated range.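

Among the compounds shown here, putting 1-(hydroxymethyl)propyl in place of hydrogen on a nitrogen on an aromatic ring gives the first step beyond the scatter in this assay, a 22-fold lower number from compound 2 to compound 3 (1.33 log units; beyond the scatter), so the number responds to substitution at this nitrogen. For the compounds shown here, the one earlier step, an at least 1.0-fold lower number from compound 1 to compound 2 (0.01 log units; that floor lies within the scatter), concerned a different place and stayed within the scatter, so it could not show this. The value of compound 1 is a limit: the limit of > 100000 nM in this assay, at which 1 of the 3 values shown sits.

The compounds shown leave open which part of the 1-(hydroxymethyl)propyl carries the step: a sec-butyl group would test the need for the hydroxyl, and the opposite stereocentre would test the defined one. On these data alone, how a longer chain, a carboxylic acid or an amine in the same place would move the number in this assay also remains open.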